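The source may report more compounds than this note shows. Statements on the series, on what has been measured and on what is new or still open speak of the compounds shown alone.

Measured compounds in an assay on cells with melanin-concentrating hormone receptor 1 (Homo sapiens) as the target, read by radioligand binding; a higher number here means a weaker inhibitor, a lower number a stronger inhibitor:

Compound 1, `CC(CNCC1CCCC1)Oc1cccc2ccc(N)nc12`, gives 100 nM.
Compound 2, `Nc1ccc2cccc(OCCNCc3ccoc3)c2n1`, gives 660 nM.
Compound 3, `CC(C)c1ccc(C(=O)NCCCOc2cccc3ccc(N)nc23)cc1`, gives 60 nM.

Compound 3 sits at the low end of the three numbers in this assay. Its gap to compound 1 is within the scatter, so the two cannot be told apart; compound 2 stands clearly higher, beyond the scatter. All three share the same core, with a basic or amide-bearing chain attached through an ether oxygen.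

Compound 4, `Nc1ccc2cccc(OCCCNC(=O)Nc3cccc(Cl)c3)c2n1`, has not been measured. Relative to compound 3 it carries (3-chlorophenyl)amino in place of 4-isopropylphenyl on a carbonyl carbon: the aryl amide becomes an aryl urea, and the para-isopropyl substitution gives way to a meta-chlorine. Among the compounds with values here, no comparable step is available among the measured compounds, so the size of the change is open. Given that compound 3 gives 60 nM and the chain length and core are unchanged, compound 4 is expected to stay close, with a step from compound 3 to compound 4 of roughly a 1.3-fold higher number from compound 3 to compound 4 (0.12 log units; within the scatter) expected, no clear direction beyond the scatter. Compound 4 is estimated at 80 nM, with a range from 25 nM to 250 nM.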

Compound 4, half-maximal inhibitory concentration: 0.9 nM
Compound 4: middle estimate off by 89-fold (1.95 log units), on the high side; the measured number lies below the stated range.
By their numbers in this assay, from the lowest: compound 4; then compounds 3 and 1 (each within the scatter of the next); then compound 2.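

In this assay, within the data shown here, the change of 4-isopropylphenyl to (3-chlorophenyl)amino on a carbonyl carbon gives a 67-fold lower number from compound 3 to compound 4 (1.82 log units; beyond the scatter) and so shows that this position can move the number far beyond the scatter, which the earlier compounds, with no comparable step among them, could not show. Among these compounds, the single step combines two differences that this pair cannot separate: the entering group adds a nitrogen with one hydrogen-bond donor, and its aromatic ring carries chlorine in place of isopropyl. No measurement at hand accounts for the size of the step.

Still open, going by these compounds, is how much of the step belongs to the urea nitrogen and how much to the chlorine; a plain phenylamino group, a 4-isopropylphenylamino group or a 3-chlorophenyl amide would divide it. Also open, on these data alone, is whether the urea holds its number with a shorter or longer chain.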